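Cytotoxicity notes on an imidazolylmethyl-aniline series

The source may report more compounds than this note shows. Statements on the series, on what has been measured and on what is new or still open speak of the compounds shown alone.

Measured so far in a toxicity assay on NIH3T3 cells (Mus musculus) for cytotoxicity, read by resazurin assay; on this read-out higher numbers stand for an effect only at larger amounts of compound and lower numbers for an effect already at smaller amounts:
- compound 1, `O=[N+]([O-])c1ccc(Cn2cncc2CNc2cccc(-c3ccccc3)c2)cc1`, gives 10000 nM.
- compound 2, `COC(=O)c1ccc(NCc2cncn2Cc2cccc(OC)c2)cc1-c1ccccc1`, has "not determined" (no result reported) in this assay, that is, no result reported.
- compound 3, `CS(=O)(=O)c1ccc(Cn2cncc2CNc2ccc(-c3nc4ccccc4s3)c(-c3ccccc3)c2)cc1`, gives > 1000 nM; this is a limit of the assay and not a number.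

Compound 2 therefore stands nowhere on the numbers shown: no number exists for it, and of the other two values one is a number and one is a limit (the limit of > 1000 nM in this assay, at which 1 of the 3 values shown sits). Among the compounds with values here, the only full number in the set belongs to compound 1.

Compound 4, `COC(=O)c1ccc(NCc2cncn2Cc2ccc(C#N)cc2)cc1-c1ccccc1`, has not been measured in this assay. It differs from compound 2 by 4-cyanophenyl in place of 3-methoxyphenyl on a saturated chain carbon bound to an aromatic nitrogen. No measured step between any pair of these compounds is available, and nothing measured here attaches an effect to this change. The step from compound 2 to compound 4 is accordingly expected to fall within the scatter of this assay, in no particular direction.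

Compound 4 is estimated at 10000 nM, with a range from 3000 nM to 30000 nM, and with a fair chance that this assay again returns only a limit.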

Compound 4, half-maximal effective concentration: > 10000 nM
Compound 4 ended at the assay's limit; the forecaster's own chance of this, stated with the estimate: 50%; the middle value sits exactly at the limit.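

No step can be read from compound 2 to compound 4: in this assay compound 2 has no reported result. Compound 4 gives > 10000 nM as a limit and not a number. The compounds shown leave open whether 4-cyanobenzyl in place of 3-methoxybenzyl changes the read-out at all.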